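Fluorine on the Allylic Chain and Microsomal Stability

This account rests on a few compounds, and the source may have more. Where it says the series, first, only, none or still open, it means among the compounds named here.

Measured so far:
Compound 2, `C/C(=C/CN)CN(C[C@H]1Cc2ccccc2CN1)[C@H]1CCCc2cccnc21`, gives 96%.
Compound 1, `N[C@H]1CC[C@H](CN(C[C@H]2Cc3ccccc3CN2)[C@H]2CCCc3cccnc32)CC1`, gives 39%.

Compound 2 stands highest of the two numbers in an ADME assay on microsomes from liver (Homo sapiens) for metabolic stability; a higher number here means that more of the compound is left, a lower number that less of the compound is left. Going by the values given here, the only other measured compound lies well below it: a number 57 percentage points higher from compound 1 to compound 2 (beyond the scatter). That step exchanged a ring-bearing group for an open chain, a different kind of change from the one now at hand.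

Compound 3, `C/C(CN(C[C@H]1Cc2ccccc2CN1)[C@H]1CCCc2cccnc21)=C(/F)CN`, differs from compound 2 by a group of 6 heavy atoms (4 carbon, 1 nitrogen, 1 fluorine; no ring) in place of a group of 5 heavy atoms (4 carbon, 1 nitrogen; no ring), on a saturated chain carbon bound to an amine nitrogen. Among the compounds with values here, no measured step adds a fluorine to this chain, so the single known step bears on the new one only loosely. With compound 2 already close to the top of the scale, little room remains upward, and no step beyond the scatter is expected: a number 6 percentage points lower from compound 2 to compound 3 (within the scatter). For compound 3 the expected value is 90%, with a range from 75% to 100%.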

Compound 3, percent of the compound remaining: 35%
Compound 3: middle estimate off by 55 percentage points, on the high side; the measured number lies below the stated range.
By their numbers in this assay, from the lowest: compounds 3 and 1 (each within the scatter of the next); then compound 2.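

In this assay, a single fluorine added to the open chain is enough to undo the high number of compound 2: a number 61 percentage points lower from compound 2 to compound 3 (beyond the scatter). The earlier compounds shown here showed a large step only when a whole ring-bearing group gave way to an open chain, whereas here a step of that size comes from a far smaller change at the same place, on a saturated chain carbon bound to an amine nitrogen. The open chain alone therefore does not secure a high number, as the other step shows: a number 4 percentage points lower from compound 1 to compound 3 (within the scatter). Nothing available here explains the loss.

Whether the loss belongs to fluorine itself remains open, since no compound shown carries a chlorine or a methyl group in its place. Also open, as far as these compounds go, is how a fully saturated chain bearing fluorine would behave.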